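Amide and urea variants: notes on a pyrazole series

The compounds below may be only part of what the source reports. "The series", "measured", "known", "first", "only" and "open" are said of these compounds alone.

Measured so far:
Compound 1, `COc1cc(-c2nn(-c3cccc(NC(=O)c4cccc(C(F)(F)F)c4)c3)cc2-c2ccncc2)ccc1Cl`, in a functional assay on NCI-H322M cells (Homo sapiens) for inhibition, read by sulforhodamine B assay, with a stated time of 48 h (a lower number here means that less compound is tolerated, a higher number that more compound is tolerated), gives > 50000 nM.
Compound 2, `COc1cc(-c2nn(-c3cccc(NC(=O)Nc4ccc(Cl)c(C(F)(F)F)c4)c3)cc2-c2ccncc2)ccc1Cl`, in this assay gives > 32500 nM.

Both values shown are limits of this assay rather than numbers. Compound 2 stands at the limit (the limit of > 32500 nM in this assay, at which 1 of the 2 values shown sits). Compound 1 stands at the limit (the limit of > 50000 nM in this assay, at which 1 of the 2 values shown sits). Within the data shown here, the only step between measured compounds, a step that the two limits leave unreadable from compound 1 to compound 2, lies between two limits and its size cannot be read.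

Compound 3, `COc1cc(-c2nn(-c3cccc(NC(=O)c4ccccc4)c3)cc2-c2ccncc2)ccc1Cl`, differs from compound 2 by phenyl in place of (4-chloro-3-(trifluoromethyl)phenyl)amino on a carbonyl carbon. No measured step bears readably on this change: the one step shown, a step that the two limits leave unreadable from compound 1 to compound 2, gives no size, so nothing in the data sets a direction for this assay here. What can be said is that compound 1, which also carries an amide on that carbonyl carbon, gives > 50000 nM in this assay.

On that basis compound 3 is expected to give 60000 nM in this assay, most likely again reported only as a limit, with a range of 20000 nM to 200000 nM. The step that the limit leaves unreadable from compound 2 to compound 3 is therefore expected to be no more than scatter.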

Compound 3, concentration lethal to 50% of the cells: > 100000 nM
Compound 3 gave a limit, no number (the forecaster's own chance of this, stated with the estimate: 85%); at least 1.6-fold (0.22 log units) between middle value and limit.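

In this assay compound 3 gives > 100000 nM, a limit and not a number. With the values of compound 1 and compound 2 also limits, neither step to compound 3 can be read. The compounds shown leave open whether the amide and urea variants differ at all in this assay.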